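The source may report more compounds than this note shows. Statements on the series, on what has been measured and on what is new or still open speak of the compounds shown alone.

Two compounds of this series have numbers in a functional assay on cardiac atrium for agonist activity at histamine H2 receptor (Cavia porcellus); on this read-out lower numbers stand for lower potency and higher numbers for higher potency (the scale is a negative logarithm). Compound 1 `Cc1ccc(C(CC/N=C(\N)NCCCc2c[nH]cn2)c2ccccn2)cc1` gives 7.71 there. Compound 2 `N=C(NCCCc1c[nH]cn1)NCCC(c1ccc(F)cc1)c1ccccn1` gives 8.01 in this assay and stands at the higher of the two numbers shown, but compound 1, its nearest neighbour, lies within the scatter of it, so the two values cannot be told apart. Compound 3 `N=C(NCCCc1c[nH]cn1)NCCC(c1cccc(F)c1)c1ccccn1` has not been measured. It differs from compound 2 in one place: 3-fluorophenyl in place of 4-fluorophenyl on a saturated chain carbon bound to an aromatic carbon and a saturated chain carbon. Within the data shown here, no measured pair shows a move of the fluorine between positions on this ring, so no measured step guides the expectation; what the two measured compounds show is only that exchanging the group on this saturated chain carbon left their values within the scatter of each other. The step in this assay is therefore expected to be none beyond the scatter, in either direction. Compound 3 is estimated to give 7.9 in this assay, with a range from 7.4 to 8.4. The expected step of a number 0.11 log units lower from compound 2 to compound 3 (within the scatter) stays within the scatter.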

Compound 3, negative logarithm of the half-maximal effective concentration: 7.88
The estimate for compound 3 lay 0.02 log units above the measured number; the range from low to high includes it.
By their numbers in this assay, from the lowest: compounds 1, 3 and 2 (each within the scatter of the next).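

Moving the fluorine on this ring gives the only step so far between two compounds that differ in one place: in this assay, the step is a number 0.13 log units lower from compound 2 to compound 3 (within the scatter). On this read-out, 3-fluorophenyl and 4-fluorophenyl on this saturated chain carbon therefore cannot be told apart, which the earlier pair could not show because it contained no such move. Nothing available bears on the reason for this result.

Still open, as far as these compounds go, is whether 2-fluorophenyl, 3,4-difluorophenyl or plain phenyl on this saturated chain carbon would also remain within the scatter of compound 2 and compound 3. Also open, from the compounds shown here alone, is whether a larger group such as 3-chlorophenyl, 3-methoxyphenyl or 3-trifluoromethylphenyl at this place would give a step beyond the scatter.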